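A few compounds are considered here, and "the series" means these few. Any claim that something is new, unique, unknown or untested is made for them only; others in the source may bear on it.

Measured so far:
compound 1, `Cn1ncc2c(=O)n(-c3ccccc3)c(SCc3cccc(F)c3)cc21`, in an assay on isolated protein for inhibition of aldehyde dehydrogenase 1A1 (Homo sapiens) (a lower number here means a stronger inhibitor, a higher number a weaker inhibitor), gives 240 nM;
compound 2, `C[C@@H](Sc1nc2c(cnn2C)c(=O)n1-c1ccccc1)c1ccccc1`, in this assay gives 70 nM.

Of these two numbers compound 2 holds the lower one, and the gap to compound 1 is wider than the usual scatter of repeated measurements, so compound 2 stands as the stronger inhibitor of the pair. The two structures are not a single-change pair, so the two values can only be set side by side; nothing is computed from them as a step.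

Compound 3, `CC(Sc1nc2c(cnn2C)c(=O)n1-c1ccccc1)c1cccc(F)c1`, has not been measured. It is made from compound 2 by one change: 1-(3-fluorophenyl)ethyl in place of 1-phenylethyl on a sulfur. The shared core and the sulfur link stay as they are; only one fluorine is added to the ring at the end of the side chain. Going by the values given here, nothing among the measured compounds isolates the effect of such an added fluorine, so the expectation rests on the small size of the change alone. The expected step of no change at the digits printed from compound 2 to compound 3 (within the scatter) is one that stays within the usual scatter, with no clear direction. Compound 3 is therefore estimated at 70 nM, within a range from 30 nM to 160 nM.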

Compound 3, half-maximal inhibitory concentration: 151 nM
Estimate against measurement, compound 3: 2.2-fold (0.33 log units) below; the measured number falls inside the stated range.
By their numbers in this assay, from the lowest: compound 2; then compounds 3 and 1 (each within the scatter of the next).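

In this assay, the step on this sulfur is modest but clear: a 2.2-fold higher number from compound 2 to compound 3 (0.33 log units; beyond the scatter) shows that the side chain here does not accept every small edit without a shift in the number. The edit is also more than one added fluorine, for the leaving 1-phenylethyl has one defined stereocentre, while the entering 1-(3-fluorophenyl)ethyl has none defined, so this single step holds both differences and cannot divide its size between them. No measurement offered here gives a reason for the step.

Still open, from the compounds shown here alone, is whether a single defined form of 1-(3-fluorophenyl)ethyl would sit closer to compound 2 or stay with compound 3, which would show how much of the step belongs to the fluorine itself. Also open, going by these compounds, is how this position would answer to a chlorine or a methoxy group on the same ring, or to an amine at the end of a longer chain on the sulfur.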